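The source may report more compounds than this note shows. Statements on the series, on what has been measured and on what is new or still open speak of the compounds shown alone.

Compound 1 `CC(C)=CCC[C@]1(C)/C=C/[C@@H](OC(=O)C=C(C)C)[C@](C)(O)/C=C/[C@H](O)/C(CO)=C\C1`: 33000 nM
Compound 2 `CO[C@@H]1/C=C/[C@@](C)(O)[C@H](OC(=O)C=C(C)C)/C=C/[C@@](C)(CCC=C(C)C)C/C=C\1CO`: 33300 nM
Compound 3 `CO[C@H]1/C=C/[C@@](C)(O)[C@H](OC(=O)C=C(C)C)/C=C/[C@@](C)(CCC=C(C)C)C/C=C\1CO`: not yet measured

In a functional assay on MCF7 cells (Homo sapiens) for antiproliferative activity, read by MTT assay, with a stated time of 48 h (on this read-out lower numbers stand for stronger inhibition and higher numbers for weaker inhibition), compound 2 at 33300 nM stands level with compound 1, the two numbers lying within the scatter of each other. Compound 3 keeps the atoms and bonds of compound 2 (the two compounds have the same atoms and bonds and differ only in configuration as drawn: 1 of 7 stereo elements differ; a stereocentre at a saturated ring carbon is drawn R in compound 2 and S in compound 3): a stereocentre at a saturated ring carbon is drawn R in compound 2 and S in compound 3. For the measured compounds named here, no measured pair isolates such a change, so no shift beyond the scatter is expected in this assay. The expected step (a 1.1-fold lower number from compound 2 to compound 3 (0.05 log units; within the scatter)) is small. Compound 3 is estimated at 30000 nM (expected range 14000 nM to 65000 nM).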

Compound 3, half-maximal inhibitory concentration: 18500 nM
For compound 3 the middle estimate is 1.6-fold (0.21 log units) above the measured one; low and high end bracket the measured number.
By their numbers in this assay, from the lowest: compounds 3, 1 and 2 (each within the scatter of the next).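

In this assay the change from R to S at a saturated ring carbon moves the number by no more than the scatter (a 1.8-fold lower number from compound 2 to compound 3 (0.26 log units; within the scatter)). Methyl in place of hydrogen on an oxygen on a saturated carbon likewise gives no shift beyond the scatter (a 1.8-fold lower number from compound 1 to compound 3 (0.25 log units; within the scatter)). The pair of compound 2 and compound 3 reads this one stereocentre alone: the fact that compounds 2 and 3 differ only in the configuration as drawn

Still open, going by these compounds, is whether a longer chain or an acetyl group on that oxygen, or an amine in its place, would give a step beyond the scatter. The other stereo elements of the shared core also remain unread on their own.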